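Replacing the Aryl Group: What to Expect for Compound 4

The compounds below may be only part of what the source reports. "The series", "measured", "known", "first", "only" and "open" are said of these compounds alone.

Compound 1 `Cc1ccc(-c2cnc(NC(=O)c3ccc(F)cc3)n2C)cc1` gives 60000 nM in a toxicity assay on THP-1 cells (Homo sapiens) for inhibition; a higher number here means that more compound is tolerated, a lower number that less compound is tolerated.
Compound 2 `Cn1c(-c2ccc([N+](=O)[O-])cc2)cnc1NC(=O)c1ccc(F)cc1` gives only a limit, > 50000 nM.
Compound 3 `COc1ccc(-c2cnc(NC(=O)C3CCCCC3)n2C)cc1` also gives only a limit, > 100000 nM.

Going by the values given here, compound 1 therefore holds the only definite number in this assay; the two other values are limits. Compound 4 `Cn1c(-c2ccccc2Br)cnc1NC(=O)c1ccc(F)cc1` differs from compound 1 by 2-bromophenyl in place of 4-methylphenyl on an aromatic carbon. Among the compounds with values here, the single measured step starting from compound 1, a step that the limit leaves unreadable from compound 1 to compound 2, cannot be sized because compound 2 sits at the limit of > 50000 nM in this assay, at which 1 of the 3 values shown sits. No readable step bears on the change, so for compound 4 no step beyond the usual scatter is expected, meaning no change at the digits printed from compound 1 to compound 4 (within the scatter). Compound 4 is thus estimated at 60000 nM, with a range from 25000 nM to 150000 nM, and a real chance that this assay again returns only a limit.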

Compound 4, half-maximal cytotoxic concentration: > 100000 nM
Compound 4 ended at the assay's limit; the forecaster's own chance of this, stated with the estimate: 40%; middle value at least 1.6-fold (0.22 log units) from the limit.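

In this assay, 2-bromophenyl in place of 4-methylphenyl gives an at least 1.6-fold higher number from compound 1 to compound 4 (0.22 log units; that floor lies within the scatter). Compound 4 gives > 100000 nM, which is a limit and not a number. Going by these compounds alone, this is the first readable step at this position, and it shows that a bromine on the aromatic ring brings no sign of lower tolerance, although the step to compound 2 cannot be read.

The change swaps the methyl for a bromine and also alters where the substituent sits on the phenyl ring, so the two effects stay unseparated. Going by these compounds, whether an amine or a carboxylic acid on that phenyl ring would lower the tolerated concentration also remains open.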